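The source may hold more compounds than are shown below. What is called first, only, known or untested is meant among the compounds shown, and "the series" means these compounds.

Measured so far in an assay on isolated protein for inhibition of long-chain fatty acid transport protein 1 (Homo sapiens); on this read-out higher numbers stand for weaker inhibition and lower numbers for stronger inhibition:
compound 1 `CCC(=O)c1ccc(N(C)C(=O)CSc2nnc(CNc3ccccc3)n2CC)cc1`: 580 nM
compound 3 `CCn1c(CNc2ccccc2)nnc1SCc1nc2cc(C(=O)C(C)C)ccc2o1`: 600 nM
Compound 2 `CCn1c(CNc2ccccc2)nnc1SCC(=O)Nc1ccc(Cl)cc1` reaches only a limit of the assay, > 1000 nM, as noted for (the limit of > 1000 nM in this assay, at which 1 of the 3 values shown sits).

Of the two numbers given, those of compound 3 and compound 1 sit within the scatter of each other, so no order between them can be read. Compound 4 `CC/C(=N/OC)c1ccc2oc(CSc3nnc(CNc4ccccc4)n3CC)nc2c1` differs from compound 3 by a group of 6 heavy atoms (4 carbon, 1 nitrogen, 1 oxygen; no ring) in place of a group of 5 heavy atoms (4 carbon, 1 oxygen; no ring), on an aromatic carbon, the site being meta to a fused ring and para to a fused ring. Within the data shown here, no measured pair isolates this exchange, and the two numbers in hand lie close together, so no step beyond the scatter is expected in this assay. For compound 4 the estimate is 700 nM, with a range from 300 nM to 1600 nM, an expected step of a 1.2-fold higher number from compound 3 to compound 4 (0.07 log units; within the scatter).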

Compound 4, half-maximal inhibitory concentration: > 1000 nM
Compound 4: a limit, no number; the forecaster's own chance of this, stated with the estimate: 25%; middle value at least 1.4-fold (0.15 log units) from the limit.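

The value of compound 4, > 1000 nM, is a limit of the assay and not a number: the limit of > 1000 nM in this assay, at which 2 of the 4 values shown sit. In this assay, exchanging isopropylcarbonyl on this aromatic carbon for the nitrogen-bearing group gives an at least 1.6-fold higher number from compound 3 to compound 4 (0.22 log units; that floor lies within the scatter), so only a floor is known and it does not establish a real loss. Among these compounds, this is the first single-place step, and at this position only isopropylcarbonyl has so far given a number.

From the compounds shown here alone, how far compound 4 lies past its limit stays open. So does how an amine, a carboxylic acid or a longer acyl chain on this aromatic carbon would read.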